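The compounds below may be only part of what the source reports. "The series", "measured", "known", "first", "only" and "open" are said of these compounds alone.

Compound 1 `CCCCNc1ccc([N+](=O)[O-])cc1S(N)(=O)=O` carries a butyl chain on the ring nitrogen, and in a physicochemical assay for solubility, in phosphate buffer, measured as kinetic solubility, at pH 7.4, tested at 250 uM (on this read-out higher numbers stand for higher solubility and lower numbers for lower solubility), compound 1 gives 85000 nM. Compound 2 `CCCCCCNc1ccc([N+](=O)[O-])cc1S(N)(=O)=O` differs from it by ethyl in place of hydrogen on a saturated chain carbon, four bonds along the chain from a nitrogen on an aromatic ring, and in this assay compound 2 gives 6000 nM; the step of a 14-fold lower number from compound 1 to compound 2 (1.15 log units; beyond the scatter) is large and beyond the scatter. Compound 3 `CCCCCCNc1ccc(C(=O)O)cc1S(=O)(=O)NC` rests on a different core, and the difference between the two cores is not broken down here. In this assay compound 3 gives 247000 nM, the highest of the three numbers, with its steps to compound 1 and compound 2 both beyond the scatter. Compound 4 `CCCCCCCCNc1ccc(C(=O)O)cc1S(=O)(=O)NC` has not yet been measured. It differs from compound 3 by ethyl in place of hydrogen on a saturated chain carbon, six bonds along the chain from a nitrogen on an aromatic ring. This is the same kind of change as that from compound 1 to compound 2, but not the same: the added ethyl sits six bonds along the chain from the ring nitrogen in compound 4, against four bonds in compound 2. Because the step of a 14-fold lower number from compound 1 to compound 2 (1.15 log units; beyond the scatter) was large, a drop is expected for compound 4 as well, estimated at a 3.5-fold lower number from compound 3 to compound 4 (0.55 log units; beyond the scatter), though smaller, since compound 3 starts from 247000 nM on a core that gives higher numbers than the core of compound 1. Compound 4 is therefore estimated at 70000 nM, between 20000 nM and 200000 nM.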

Compound 4, solubility: 53000 nM
The estimate for compound 4 lay 1.3-fold (0.12 log units) above the measured number; the measured number falls inside the stated range.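

In this assay the change carries across in direction: a 4.7-fold lower number from compound 3 to compound 4 (0.67 log units; beyond the scatter) runs the same way as a 14-fold lower number from compound 1 to compound 2 (1.15 log units; beyond the scatter), and both steps lie beyond the scatter, the first printed as modest and the second as large. This does not show that the size of the step carries from one core to the other, since the core and the place of the added ethyl differ together between the two pairs, six bonds along the chain from the ring nitrogen in compound 4 against four bonds in compound 2, and two pairs cannot tell these apart. Nothing available bears on what lies behind either step.

The compounds shown leave open how a chain longer than that of compound 4 would read on the core it shares with compound 3, and whether the number would keep falling. From the compounds shown here alone, how a chain carrying an amine would read on either core also stays open.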